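The compounds below may be only part of what the source reports. "The series", "measured", "known", "first", "only" and "open" are said of these compounds alone.

Measured so far, in a functional assay for antagonist activity at melanin-concentrating hormone receptor 1 (Homo sapiens); on this read-out higher numbers stand for weaker inhibition and lower numbers for stronger inhibition:
compound 1, `N#Cc1cccc(-c2ccc(CN(CCN3CCCC3)C(=O)Nc3ccc(F)c(Cl)c3)cc2)c1`, gives 287 nM;
compound 2, `C[C@H](c1ccc(-c2cccc(C#N)c2)cc1)N(CC(=O)Nc1cc(Cl)cc(Cl)c1)C(=O)CCN1CC[C@H](O)C1`, gives 23 nM;
compound 3, `C[C@@H](c1ccc(-c2cccc(C#N)c2)cc1)N(CC(=O)Nc1cc(Cl)cc(Cl)c1)C(=O)CCN1CC[C@H](O)C1`, gives 18 nM.

Compound 2 stands second highest of the three numbers in this assay. Its nearest neighbour is compound 3, reached by a 1.3-fold lower number from compound 2 to compound 3 (0.11 log units; within the scatter); the two differ only in the configuration drawn at one saturated chain carbon (the fact that compounds 2 and 3 differ only in the configuration as drawn). Compound 1 lies furthest away, with the higher number.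

Compound 4, `C[C@H](c1ccc(-c2cccc(C#N)c2)cc1)N(CC(=O)Nc1cc(Cl)cc(Cl)c1)C(=O)CCCN1CC[C@H](O)C1`, is compound 2 with one change: (3-hydroxypyrrolidin-1-yl)methyl in place of 3-hydroxypyrrolidin-1-yl on a saturated chain carbon, two bonds along the chain from a carbonyl carbon. Read one bond further out, the same difference is (2-(3-hydroxypyrrolidin-1-yl)ethyl)carbonyl becoming (3-(3-hydroxypyrrolidin-1-yl)propyl)carbonyl.

For the measured compounds named here, none of the measured steps bears on this change. Going by the values given here, the only step with a single difference, from compound 2 to compound 3, concerns a configuration, and it stayed within the scatter. Compound 1 differs from compound 2 in several places at once, so its higher number cannot be tied to the chain alone. Among the compounds with values here, no measured step therefore points in either direction, and the expectation is a step no larger than the scatter.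

The step of a 1.1-fold higher number from compound 2 to compound 4 (0.04 log units; within the scatter) is the expected outcome of this change. Compound 4 is accordingly estimated at 25 nM in this assay, with a range from 8 nM to 80 nM.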

Compound 4, inhibition constant: 76 nM
The estimate for compound 4 lay 3.0-fold (0.48 log units) below the measured number, and the stated range covers the measured number.
By their numbers in this assay, from the lowest: compounds 3 and 2 (each within the scatter of the next); then compound 4; then compound 1.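

In this assay, adding one carbon to the chain that carries the 3-hydroxypyrrolidin-1-yl group is not a neutral change, since it gives a 3.3-fold higher number from compound 2 to compound 4 (0.52 log units; beyond the scatter) on this compound pair. The earlier compounds showed only a change of configuration, a 1.3-fold lower number from compound 2 to compound 3 (0.11 log units; within the scatter) and within the scatter, so this is the first single-place step shown to move the number beyond the scatter, and it marks this saturated chain carbon, two bonds along the chain from a carbonyl carbon, as a place where chain length matters. Nothing given here explains why the extra carbon has this effect.

From the compounds shown here alone, it remains open whether a still longer chain, such as 4-(3-hydroxypyrrolidin-1-yl)butyl, would raise the number further, and whether the extra carbon acts the same way in the configuration of compound 3. A plain pyrrolidin-1-yl or a piperidin-1-yl group on the same chain also remains to be compared.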